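A few compounds are considered here, and "the series" means these few. Any claim that something is new, unique, unknown or untested is made for them only; others in the source may bear on it.

Measured so far:
compound 1, `CN(C)CCn1cnnc1-c1cc(Oc2ccc(NC(=O)Nc3ccc(F)c(Cl)c3)cc2F)ccn1`, 63.3%
compound 2, `CCN(CC)CCn1cnnc1-c1cc(Oc2ccc(NC(=O)Nc3cccc(C(F)(F)F)c3)cc2F)ccn1`, 72.1%
compound 3, `CCN(CC)CCn1cnnc1-c1cc(Oc2ccc(NC(=O)Nc3ccccc3C(F)(F)F)cc2F)ccn1`, "not determined" (no result reported)

In an assay on isolated protein for inhibition of proto-oncogene tyrosine-protein kinase receptor Ret (Homo sapiens), read by mobility shift assay, with a stated time of 1 h, tested at 10 uM (on this read-out higher numbers stand for more inhibition at the one concentration tested (going by the name of the read-out) and lower numbers for less inhibition), compound 1 gives 63.3% and compound 2 gives 72.1%. These two values lie within the usual scatter of each other, so no order can be read from them. On these data alone, compound 3, `CCN(CC)CCn1cnnc1-c1cc(Oc2ccc(NC(=O)Nc3ccccc3C(F)(F)F)cc2F)ccn1`, gives "not determined" (no result reported) in this assay, so there is no number for it to start from, and its standing remains open. Compound 4, `CCN(CC)CCn1cnnc1-c1cc(Oc2ccc(NC(=O)Nc3ccc(F)c(Cl)c3)cc2F)ccn1`, differs from compound 3 in one place: 3-chloro-4-fluorophenyl in place of 2-(trifluoromethyl)phenyl on an amide-type nitrogen. The group that enters is the very group compound 1 carries, while everything else in compound 4 matches compound 2. Going by the values given here, no step between measured compounds exists here, so no step size can be computed in this assay for this change and none beyond the scatter is assumed; the two measured compounds simply bracket a narrow band. Compound 4 is therefore expected to land near that band, at an estimated 68% with a range of 52% to 82%.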

Compound 4, a percentage reported as inhibition, at one concentration (the size of the read-out at that concentration, not a potency): 1.9%
Compound 4: middle estimate off by 66.1 percentage points, on the high side; measured number outside the range, below it.
By their numbers in this assay, from the lowest: compound 4; then compounds 1 and 2 (each within the scatter of the next).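

Until now, compounds 1 and 2 differed in two places, so neither change could be seen alone. In this assay, with 3-chloro-4-fluorophenyl held on the amide-type nitrogen, diethylamino in place of dimethylamino on the chain gives a number 61.4 percentage points lower from compound 1 to compound 4 (beyond the scatter), while with diethylamino held, 3-chloro-4-fluorophenyl in place of 3-(trifluoromethyl)phenyl gives a number 70.2 percentage points lower from compound 2 to compound 4 (beyond the scatter); among these compounds, diethylamino goes with a high number alongside 3-(trifluoromethyl)phenyl and a very low one alongside 3-chloro-4-fluorophenyl, so the two ends of the molecule cannot be judged separately. Nothing measured here says why the number falls so far.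

The step from compound 3 cannot be read, as that compound has no result. On these data alone, it remains open how dimethylamino would read alongside 3-(trifluoromethyl)phenyl, and how a ring amine such as morpholine would read at the end of the chain.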